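Cytotoxicity of a Benzofuran Analogue Expected from Limits

This account rests on a few compounds, and the source may have more. Where it says the series, first, only, none or still open, it means among the compounds named here.

Compound 1 `CC(=O)c1ccc(NCc2cncn2Cc2ccc(-c3ccccc3)cc2)cc1-c1ccccc1` gives a limit, > 10000 nM, in a toxicity assay on NIH3T3 cells (Mus musculus) for cytotoxicity, read by resazurin assay; on this read-out lower numbers stand for an effect already at smaller amounts and higher numbers for an effect only at larger amounts of compound.
Compound 2 `CN(C)c1ccc(NCc2cncn2Cc2ccc(-c3ccccc3)cc2)cc1-c1ccccc1` gives a limit, > 1000 nM.
Compound 3 `COC(=O)c1ccc(NCc2cncn2Cc2ccc(-c3ccccc3)cc2)cc1-c1ccccc1` gives a limit, > 1000 nM.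

Compound 3 thus stands at the limit of > 1000 nM in this assay, at which 2 of the 3 values shown sit, while compound 1 stands at the limit of > 10000 nM in this assay, at which 1 of the 3 values shown sits. The change to compound 4 `c1ccc(-c2ccc(Cn3cncc3CNc3ccc(-c4cc5ccccc5o4)c(-c4ccccc4)c3)cc2)cc1` is 1-benzofuran-2-yl in place of methoxycarbonyl on an aromatic carbon. The steps that touch this position, a step that the two limits leave unreadable from compound 2 to compound 3 and a step that the two limits leave unreadable from compound 1 to compound 3, give no readable size, so no direction can be drawn from them. With every measured compound at a limit, compound 4 is expected to stay near the same region, and the step from compound 3 is estimated as a step that the limit leaves unreadable from compound 3 to compound 4. For compound 4 the estimate in this assay is 5000 nM, within 1000 nM to 30000 nM.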

Compound 4, half-maximal effective concentration: > 10000 nM
Compound 4 ended at the assay's limit; the forecaster's own chance of this, stated with the estimate: 70%; middle value at least 2.0-fold (0.30 log units) away from the limit.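

Compound 4 gives only a limit, as do compound 1, compound 2 and compound 3, so none of the steps between compound 4 and these three can be read. In this assay the compounds shown leave open what size any of these group changes has.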